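Working notes: moving the methoxy group on compound 1

The compounds below may be only part of what the source reports. "The series", "measured", "known", "first", "only" and "open" are said of these compounds alone.

Measured compounds and their values in an in vitro functional assay on cells for agonist activity at Bombesin receptor subtype-3 (Mus musculus), read by luminescence and calcium flux; on this read-out lower numbers stand for an effect already at smaller amounts and higher numbers for an effect only at larger amounts of compound:
compound 1 with structure `COc1ccc(Cc2cnc(CCc3ccc(-c4ccccc4C(=O)O)cc3)[nH]2)cc1` gives 513 nM
compound 2 with structure `O=C(O)c1ccccc1-c1ccc(CCc2ncc(Cc3cccc(F)c3)[nH]2)cc1` gives 7.9 nM
compound 3 with structure `CCC(C)(CC)Cc1cnc(CCc2ccc(-c3ccccc3C(=O)O)cc2)[nH]1` gives 30 nM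

Compound 1 stands highest of the three numbers. Its nearest neighbour is compound 3, reached by a 17-fold lower number from compound 1 to compound 3 (1.23 log units; beyond the scatter) and its furthest is compound 2, reached by a 65-fold lower number from compound 1 to compound 2 (1.81 log units; beyond the scatter) so both changes at this place lower the number well beyond the scatter. Between the two lower compounds the step is a 3.8-fold higher number from compound 2 to compound 3 (0.58 log units; beyond the scatter) which is modest.

Compound 4 with structure `COc1ccccc1Cc1cnc(CCc2ccc(-c3ccccc3C(=O)O)cc2)[nH]1` is still to be measured in this assay and differs from compound 1 by 2-methoxyphenyl in place of 4-methoxyphenyl on a saturated chain carbon bound to an aromatic carbon

Among the measured compounds shown here, the two measured steps from compound 1 both swap the 4-methoxyphenyl for something else and both point the same way, toward lower numbers, but neither keeps a methoxyphenyl, so there is no direct precedent for exchanging 4-methoxyphenyl for 2-methoxyphenyl. A step toward lower numbers is expected, but one of modest size, smaller than either measured replacement. For compound 4 the expected value in this assay is 160 nM with an expected range from 40 nM to 600 nM and this estimate corresponds to an expected step of a 3.2-fold lower number from compound 1 to compound 4 (0.51 log units; beyond the scatter)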

Compound 4, half-maximal effective concentration: 163 nM
The estimate for compound 4 lay 1.0-fold (0.01 log units) below the measured number; the measured number falls inside the stated range.
By their numbers in this assay, from the lowest: compound 2; then compound 3; then compound 4; then compound 1.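

In this assay, among the compounds shown here, the earlier steps at this place each replaced the whole 4-methoxyphenyl group, whereas this change keeps the same atoms and the same counts, and moving to 2-methoxyphenyl alone gives a 3.1-fold lower number from compound 1 to compound 4 (0.50 log units; beyond the scatter). The number at this place therefore depends on how the methoxy group is placed on the ring, and not only on which group is present. That gain remains only a partial one, with a 5.4-fold higher number from compound 3 to compound 4 (0.74 log units; beyond the scatter) and a 21-fold higher number from compound 2 to compound 4 (1.31 log units; beyond the scatter), so the 2-methoxyphenyl of compound 4 stays behind both the 1-ethyl-1-methylpropyl group of compound 3 and the 3-fluorophenyl group of compound 2; no evidence at hand accounts for these differences.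

As far as these compounds go, it remains open whether the methoxy group contributes at all, and a plain phenyl ring, or a hydroxyl or an amine in place of the methoxy, would begin to settle how much of the change between compound 1 and compound 4 belongs to that group. The step to compound 2 also changes both the substituent and its placement, so the share of each in its low number stays unresolved.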